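Enantiomer of compound 3 in the caudal artery assay

This account rests on a few compounds, and the source may have more. Where it says the series, first, only, none or still open, it means among the compounds named here.

Measured so far:
compound 1 `COC(=O)[C@@H]1c2cc(/C=C/C(=O)NCCCCNC(=N)N)ccc2O[C@H]1c1ccc(O)cc1`: 9720000 nM
compound 2 `N=C(N)NCCCCNC(=O)/C=C/c1ccc(O)cc1`: > 100000000 nM
compound 3 `N=C(N)NCCCCNC(=O)[C@@H]1c2cc(/C=C/C(=O)O)ccc2O[C@H]1c1ccc(O)cc1`: > 100000000 nM

Where compound 3 stands: in a functional assay on Caudal artery for antagonist activity at Alpha-1A adrenergic receptor (Rattus norvegicus) (a lower number here means a stronger inhibitor, a higher number a weaker inhibitor), compound 3 reports only a limit, > 100000000 nM, not a number. Compound 2 likewise reports only a limit in this assay, > 100000000 nM. Among the compounds with values here, compound 1 is the only one with a number, 9720000 nM, and it is a weak inhibitor by any reading. The run is thus dominated by the limit of > 100000000 nM in this assay, at which 2 of the 3 values shown sit.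

The step to compound 4 `N=C(N)NCCCCNC(=O)[C@H]1c2cc(/C=C/C(=O)O)ccc2O[C@@H]1c1ccc(O)cc1` changes no atom or bond: the two compounds have the same atoms and bonds; at least one stereo element is drawn with a configuration in one of them and without one in the other: 2 of 4 stereo elements differ; a stereocentre at a saturated ring carbon is drawn R in compound 3 and S in compound 4; a stereocentre at a saturated ring carbon is drawn R in compound 3 and S in compound 4. Compound 4 is the mirror image of compound 3 at both saturated ring carbons. Within the data shown here, no measured step covers such an inversion, so nothing here shows how much the two configurations differ.

Given that compound 3 sits at the limit, the expected step from compound 3 to compound 4 in this assay is a number no higher from compound 3 to compound 4 (the limit leaves the size open), that is, none beyond the scatter with the limit most likely reported again. For compound 4 the estimate in this assay is 100000000 nM, with a range from 10000000 nM to 1000000000 nM.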

Compound 4, half-maximal inhibitory concentration: > 100000000 nM
Compound 4: only a limit was reported; the forecaster's own chance of this, stated with the estimate: 70%; the middle value lies on the limit itself.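

In this assay, within the data shown here, compound 4 gives > 100000000 nM, a limit and not a number, and compound 3 likewise reports only a limit, so no step between these two mirror images can be read: the limit of > 100000000 nM in this assay, at which 3 of the 4 values shown sit. The compounds shown leave open whether inverting both saturated ring carbons changes inhibition in this assay at all.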